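Methyl for Hydrogen at the Amine, Carried to a Second Core

The source may report more compounds than this note shows. Statements on the series, on what has been measured and on what is new or still open speak of the compounds shown alone.

Compound 1 `C=C(c1ccc(OC)cc1NC(=O)CNC)c1ccc(OC)c2c1OC(C)(C)C=C2` and compound 3 `C=C(c1ccc(OC)cc1NC(=O)CNCC)c1ccc(OC)c2c1OC(C)(C)C=C2` share one core, and compound 2 `C=C(c1ccc2c(c1)C=CC(C)(C)O2)c1ccc(OC)cc1NC(=O)CNC` and compound 4 `C=C(c1ccc2c(c1)C=CC(C)(C)O2)c1ccc(OC)cc1NC(=O)CNCC` share another; how the two cores differ is not broken down here. In a functional assay on A2780 cells (Homo sapiens) for antiproliferative activity, read by MTT assay, with a stated time of 48 h (on this read-out lower numbers stand for stronger inhibition and higher numbers for weaker inhibition), compound 1 gives 210 nM, compound 3 gives 1030 nM, and compound 2 gives 320 nM. Within the first pair, the change methyl in place of hydrogen on a saturated chain carbon bound to an amine nitrogen made a step of a 4.9-fold higher number from compound 1 to compound 3 (0.69 log units; beyond the scatter). The same change, (methyl in place of hydrogen on a saturated chain carbon bound to an amine nitrogen), now leads from compound 2 to the unmeasured compound 4. Going by the values given here, since the two changes occur at the same place and in the same surroundings as far as they are described, the one step already seen is the only guide, and it is taken over for compound 4. The step from compound 2 to compound 4 in this assay is therefore expected to be a 4.4-fold higher number from compound 2 to compound 4 (0.64 log units; beyond the scatter), resting on the measured step from compound 1 to compound 3. Compound 4 is estimated at 1400 nM, with a range from 600 nM to 3500 nM.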

Compound 4, half-maximal inhibitory concentration: 1870 nM
Beside the measured number, compound 4's estimate is 1.3-fold (0.13 log units) below it; the range from low to high includes it.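

In this assay, the change from methylamino to ethylamino on the second core gave a 5.8-fold higher number from compound 2 to compound 4 (0.77 log units; beyond the scatter), so the loss of activity seen on the first core appeared again. Going by these compounds alone, the two steps point the same way and do not differ in size: the same change on two cores in this assay, a 4.9-fold higher number (0.69 log units; beyond the scatter) from compound 1 to compound 3 and a 5.8-fold higher number (0.77 log units; beyond the scatter) from compound 2 to compound 4, 1.2-fold (0.08 log units) apart, within the scatter of two such steps Within this series, then, the change carried over from one core to the other in this assay, but that rests on only two matched pairs and says nothing about any other core or any other assay, nor does it explain why the ethylamino compounds give higher numbers.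

The compounds shown leave open whether the trend continues with a longer chain such as propylamino, and how a primary amine or a dimethylamino group would compare at the same place. They also leave open whether a branched group such as isopropylamino, or a cyclic amine such as pyrrolidine, would follow the same step on both cores.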